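Carboxy in Place of Heptyl on the Core Nitrogen

A few compounds are considered here, and "the series" means these few. Any claim that something is new, unique, unknown or untested is made for them only; others in the source may bear on it.

Compound 1 `CCCCCCCCn1nc(-c2cccnc2)c2ccccc2c1=O`: 21900 nM
Compound 2 `O=c1c2ccccc2c(-c2cccnc2)nn1CC1CCCCC1`: 209 nM
Compound 3 `O=C(c1cccs1)n1nc(-c2cccnc2)c2ccccc2c1=O`: 12300 nM

In a functional assay (trachea) with Cavia porcellus as the target (a lower number here means a stronger inhibitor, a higher number a weaker inhibitor), compound 1 gives 21900 nM, the highest of the three numbers. Its nearest neighbour is compound 3 with 12300 nM, separated by a 1.8-fold lower number from compound 1 to compound 3 (0.25 log units; within the scatter). Compound 2 stands furthest away at 209 nM, reached by a 100-fold lower number from compound 1 to compound 2 (2.02 log units; beyond the scatter).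

Compound 4 `O=C(O)Cn1nc(-c2cccnc2)c2ccccc2c1=O` differs from compound 1 at a single place: carboxy in place of heptyl on a saturated chain carbon bound to an aromatic nitrogen.

Two measured steps start at compound 1. a 1.8-fold lower number from compound 1 to compound 3 (0.25 log units; within the scatter) exchanges the entire group on the aromatic nitrogen and stays within the scatter. a 100-fold lower number from compound 1 to compound 2 (2.02 log units; beyond the scatter) keeps a saturated chain carbon bound to the aromatic nitrogen and gives a large gain. Neither step brings in a carboxy group or a hydrogen-bond donor, so the two steps only frame the expectation loosely. The gain seen in compound 2 cannot be carried over to a group it does not share, and the move to compound 4 is expected to sit within the scatter or to raise the number somewhat. Compound 4 is therefore expected at 35000 nM, within 8000 nM to 150000 nM, which amounts to an estimated step of a 1.6-fold higher number from compound 1 to compound 4 (0.20 log units; within the scatter).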

Compound 4, half-maximal inhibitory concentration: > 100000 nM
Compound 4: only a limit was reported; the forecaster's own chance of this, stated with the estimate: 35%; at least 2.8-fold (0.45 log units) between middle value and limit.
By their numbers in this assay, from the lowest: compound 2; then compounds 3 and 1 (each within the scatter of the next). At a limit, above all of these: compound 4.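

Compound 4 is reported only as a limit of the assay, not as a number: the limit of > 100000 nM in this assay, at which 1 of the 4 values shown sits. Even so, this assay gives a clear reading of the step, an at least 4.5-fold higher number from compound 1 to compound 4 (0.65 log units; beyond the scatter), and it is the first change from compound 1 in this set that raises the number beyond the scatter, whereas the two earlier changes from that compound lowered it or stayed within the scatter. The same reading holds against the other two compounds, an at least 8.1-fold higher number from compound 3 to compound 4 (0.91 log units; beyond the scatter) and an at least 470-fold higher number from compound 2 to compound 4 (2.67 log units; beyond the scatter), so the group on the saturated chain carbon bound to the aromatic nitrogen can move the number strongly in either direction, with cyclohexyl on the favourable side and carboxy on the unfavourable one.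

The compounds shown leave open whether the rise comes from the carboxylic acid itself or simply from losing the heptyl chain, a question that a methyl ester or a primary amide on the same carboxymethyl group, or a short alkyl chain such as ethyl, would help to separate. They also leave open how far past its limit compound 4 actually lies.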